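The source may hold more compounds than are shown below. What is called first, only, known or untested is meant among the compounds shown, and "the series" means these compounds.

In an ADME assay on MT4 cells (Homo sapiens) for cytotoxicity, read by MTT assay, with a stated time of 5 days (on this read-out higher numbers stand for lower toxicity in this test and lower numbers for higher toxicity in this test), compound 3 `COc1cc2nc([S+]([O-])CC(=O)Nc3ccc(S(N)(=O)=O)cc3)nc(Nc3c(Cl)cc(/C=C/C#N)cc3Cl)c2cc1OC` gives > 189000 nM, which is a limit of the assay and not a number. Compound 1 `COc1cc2nc([S+]([O-])CC(=O)Nc3ccccc3F)nc(Nc3c(Cl)cc(/C=C/C#N)cc3Cl)c2cc1OC` gives > 208000 nM, which is likewise a limit. Compound 2 `COc1cc2nc([S+]([O-])CC(=O)Nc3cccc(C(F)(F)F)c3)nc(Nc3c(Cl)cc(/C=C/C#N)cc3Cl)c2cc1OC` gives a number, 21800 nM. Compound 4 `COc1cccc(NC(=O)C[S+]([O-])c2nc(Nc3c(Cl)cc(/C=C/C#N)cc3Cl)c3cc(OC)c(OC)cc3n2)c1` differs from compound 3 by 3-methoxyphenyl in place of 4-sulfamoylphenyl on an amide-type nitrogen, with 3-methoxyphenyl in place of 4-sulfamoylphenyl on an amide-type nitrogen. Within the data shown here, two measured steps bear on this change, both beyond the scatter: an at least 9.5-fold lower number from compound 1 to compound 2 (0.97 log units; beyond the scatter) and an at least 8.6-fold higher number from compound 2 to compound 3 (0.93 log units; beyond the scatter). Going by these compounds, compound 2 thus shows that exchanging this aromatic group can lower the number, although 3-methoxyphenyl itself is untested. A lower number is therefore expected, with the estimated step being an at least 3.1-fold lower number from compound 3 to compound 4 (0.49 log units; beyond the scatter). For compound 4 the estimate is 60000 nM, with an expected range of 15000 nM to 200000 nM.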

Compound 4, half-maximal cytotoxic concentration: >= 167000 nM
Compound 4: a limit, no number; the forecaster's own chance of this, stated with the estimate: 40%; middle value at least 2.7-fold (0.44 log units) away from the limit.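

In this assay, methoxy in place of trifluoromethyl on an aromatic carbon gives an at least 7.6-fold higher number from compound 2 to compound 4 (0.88 log units; beyond the scatter). The lower number thus stays with the 3-(trifluoromethyl)phenyl of compound 2 and does not carry over to the 3-methoxyphenyl of compound 4. The result for compound 4 is a limit and not a number: the limit of >= 167000 nM in this assay, at which 1 of the 4 values shown sits.

The steps from compound 1 and compound 3 to compound 4 cannot be read, so the order among these three stays open. Also open, going by these compounds, is how an amine or a carboxylic acid on this phenyl ring would read in this assay.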